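The compounds below may be only part of what the source reports. "The series", "measured", "known", "first", "only" and "open" are said of these compounds alone.

In a functional assay on K562 cells (Homo sapiens), read by MTT assay, with a stated time of 72 h (a lower number here means a stronger inhibitor, a higher number a weaker inhibitor), three compounds have been measured:
- Compound 1 `Cc1ncnc2c1c(-c1ccoc1)cn2[C@@H]1O[C@H](CO)[C@@H](O)[C@H]1O` gives > 20000 nM (a limit of the assay)
- Compound 2 `Cc1ncnc2c1c(-c1cccs1)cn2[C@@H]1O[C@H](CO)[C@@H](O)[C@H]1O` gives > 20000 nM (a limit of the assay)
- Compound 3 `C#Cc1cn([C@@H]2O[C@H](CO)[C@@H](O)[C@H]2O)c2ncnc(C)c12` gives 110 nM (a measured number)

Compound 3 is the only one of the three with a number, and the other two values rest on the limit of > 20000 nM in this assay, at which 2 of the 3 values shown sit, as limits. Compound 4 `Cc1ncnc2c1c(I)cn2[C@@H]1O[C@H](CO)[C@@H](O)[C@H]1O` has not yet been measured. It carries iodo in place of ethynyl on an aromatic carbon. Going by the values given here, two measured steps bear on this change only indirectly: an at least 180-fold lower number from compound 1 to compound 3 (2.25 log units; beyond the scatter) and an at least 180-fold lower number from compound 2 to compound 3 (2.25 log units; beyond the scatter) are both large. In these three compounds, the ring-bearing groups furan-3-yl and thiophen-2-yl sit at the limit, while ethynyl, which has no ring, gives a number. Iodo also has no ring, so compound 4 is not expected to fall to the limit. However, no measured step starts from or leads to iodo, so the size of the change remains uncertain. Starting from compound 3 at 110 nM, a modest move towards a higher number in this assay is expected, with an estimated 4.5-fold higher number from compound 3 to compound 4 (0.66 log units; beyond the scatter) as the result. For compound 4 the estimated value is 500 nM, with an expected range from 60 nM to 6000 nM as its bounds.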

Compound 4, half-maximal inhibitory concentration: > 20000 nM
Compound 4 gave a limit, no number; the forecaster's own chance of this, stated with the estimate: 15%; middle value at least 40-fold (1.60 log units) from the limit.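

In this assay compound 4 gives > 20000 nM, which is a limit of the assay and not a number. Putting iodo in place of ethynyl on this aromatic carbon of the five-membered ring gives an at least 180-fold higher number from compound 3 to compound 4 (2.25 log units; beyond the scatter), so having no ring is not enough to keep a compound off the limit, and compound 4 goes against the reading that only ring-bearing groups sit there; among the four compounds, ethynyl alone gives a number. The steps from compound 1 and from compound 2 to compound 4 cannot be read, and no order can be drawn among these three compounds, since all of them now rest on the same limit: the limit of > 20000 nM in this assay, at which 3 of the 4 values shown sit.

The compounds shown leave open whether ethynyl is alone in giving a number at this position, or whether other small groups such as methyl, a nitrile or an amine would also do so. They also leave open whether a longer chain ending in a triple bond, such as propynyl, would keep a number close to that of compound 3 at 110 nM.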